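Swapping the Anilide Ring: a Nitro Group for Two Methyls

The compounds below may be only part of what the source reports. "The series", "measured", "known", "first", "only" and "open" are said of these compounds alone.

Measured compounds and their values:
- compound 1 `CC(=O)c1ccc(NC(=O)CSc2snnc2-c2ccc(Br)cc2Br)c(Br)c1`: > 206000 nM
- compound 2 `Cc1cccc(C)c1NC(=O)CSc1snnc1-c1ccc(Br)cc1Br`: >= 198000 nM
- compound 3 `Cc1ccc2sc(NC(=O)CSc3snnc3-c3ccc(Br)cc3Br)nc2c1`: 23600 nM

All three share one core, a thiadiazole bearing a dibromophenyl group and a thioacetamide linker, and differ only in the aryl group on the amide nitrogen. In an ADME assay on MT4 cells (Homo sapiens) for cytotoxicity, read by MTT assay, with a stated time of 5 days (on this read-out higher numbers stand for lower toxicity in this test and lower numbers for higher toxicity in this test), compound 1 gives > 206000 nM, which is a limit of the test and not a number. In this assay compound 2 gives >= 198000 nM, again a limit rather than a measured number; it sits at the limit of >= 198000 nM in this assay, at which 1 of the 3 values shown sits. For the measured compounds named here, compound 3 is the one compound with a real number, 23600 nM, so among the values shown compound 2 stands at the untoxic end together with compound 1.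

Compound 4 `O=C(CSc1snnc1-c1ccc(Br)cc1Br)Nc1ccccc1[N+](=O)[O-]` is not yet measured. It differs from compound 2 by 2-nitrophenyl in place of 2,6-dimethylphenyl on an amide-type nitrogen. Going by the values given here, no measured pair shows a change of this kind, so the expectation rests only on the other anilides: compound 1 and compound 2 both gave limits. For compound 4 a value near the limit is expected in this assay, with a step of an at least 1.3-fold lower number from compound 2 to compound 4 (0.12 log units; that floor lies within the scatter) meaning little change beyond the scatter, possibly a slight move toward toxicity. The estimate for compound 4 is 150000 nM, between 40000 nM and 300000 nM.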

Compound 4, half-maximal cytotoxic concentration: > 235000 nM
Compound 4: a limit, no number; the forecaster's own chance of this, stated with the estimate: 55%; middle value at least 1.5-fold (0.19 log units) from the limit.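

In this assay compound 4 gives > 235000 nM, which is a limit and not a number. Compound 2 also has only a limit, so no step can be read between compound 2 and compound 4. The compounds shown leave open the true value of each, and how 2-nitrophenyl compares with 2,6-dimethylphenyl on an amide-type nitrogen.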